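A few compounds are considered here, and "the series" means these few. Any claim that something is new, unique, unknown or untested is made for them only; others in the source may bear on it.

The measured compounds are compound 1 `CCN(CC)c1ccc(NC(=O)c2c(-c3c(Cl)cccc3Cl)noc2C)c(C(F)(F)F)c1`, compound 2 `CCN(CC)c1ccc(NC(=O)c2c(-c3c(Cl)cccc3Cl)noc2CCC2OCCCO2)c(C)c1` and compound 3 `CCc1cc(N(CC)CC)ccc1NC(=O)c1c(-c2c(Cl)cccc2Cl)noc1C`. In an assay on isolated protein for binding affinity to growth hormone secretagogue receptor type 1 (Homo sapiens) (on this read-out lower numbers stand for stronger inhibition and higher numbers for weaker inhibition), compound 1 gives 4100 nM, compound 2 gives 9 nM, and compound 3 gives 370 nM.

Among the three values, compound 3 stands in the middle: its number lies below that of compound 1 and above that of compound 2. Among the compounds with values here, the one single-point step that has been measured runs into compound 3: an 11-fold lower number from compound 1 to compound 3 (1.04 log units; beyond the scatter).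

Compound 4 `CCN(CC)c1ccc(NC(=O)c2c(-c3c(Cl)cccc3Cl)noc2C)c(C)c1` has not yet been measured in this assay. It differs from compound 3 in one place: hydrogen in place of methyl on a saturated chain carbon bound to an aromatic carbon. Within the data shown here, no measured pair shows this exact change. The step from compound 1 to compound 3 shows that the group at this place matters strongly, but it concerns a different exchange. Compound 2 carries the methyl of compound 4, yet it also bears a different group elsewhere on the shared core, so its low number cannot be attributed to the methyl alone.

Given these pointers, compound 4 is expected to show a moderate change of a 3.1-fold lower number from compound 3 to compound 4 (0.49 log units; beyond the scatter) towards a lower number. The estimate for compound 4 in this assay is 120 nM, with a range from 30 nM to 500 nM.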

Compound 4, half-maximal inhibitory concentration: 37 nM
Compound 4: middle estimate off by 3.2-fold (0.51 log units), on the high side; the measured number falls inside the stated range.
By their numbers in this assay, from the lowest: compound 2; then compound 4; then compound 3; then compound 1.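

On the aromatic carbon of the shared core, shortening ethyl to methyl is worth as much as the earlier change from trifluoromethyl to ethyl in this assay (a 10-fold lower number from compound 3 to compound 4 (1.00 log units; beyond the scatter)). Together with the step from trifluoromethyl directly to methyl (a 110-fold lower number from compound 1 to compound 4 (2.04 log units; beyond the scatter)), this puts the three groups in a clear order at this place: methyl gives the lowest number, ethyl a higher one and trifluoromethyl the highest. With methyl now held constant, compound 4 also isolates the change at the other place, where the methyl of compound 4 stands in compound 2 as a chain carrying a six-membered non-aromatic ring, and replacing that group with hydrogen raises the number (a 4.1-fold higher number from compound 2 to compound 4 (0.61 log units; beyond the scatter)).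

The compounds shown leave open whether a hydrogen, a chlorine or a methoxy group on that aromatic carbon would give a still lower number than methyl, and whether an amine or a carboxylic acid at the end of the chain in compound 2 would match its ring-bearing group. Nothing available accounts for the size of these steps.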